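From a Diisopropylamine Arm to a Methylpiperazine Arm

This account rests on a few compounds, and the source may have more. Where it says the series, first, only, none or still open, it means among the compounds named here.

Among the measured compounds shown here, compound 2 `CCCCCCCCCCCCCC[C@H](OCOC)[C@H](CN(C(C)C)C(C)C)NC(=O)OC(C)(C)C` stands highest among the two compounds measured so far in a functional assay on MCF7 cells (Homo sapiens) for antiproliferative activity, read by sulforhodamine B assay, with a stated time of 48 h, tested at 10 uM (on this read-out lower numbers stand for less inhibition and higher numbers for more inhibition at the one concentration tested (going by the name of the read-out)), where compound 2 gives 26.9%. Compound 1 `CCCCCCCCCCCCCC[C@H](OCOC)[C@H](CO[Si](c1ccccc1)(c1ccccc1)C(C)(C)C)NC(=O)OC(C)(C)C` lies beyond the usual scatter below it; in this assay compound 1 gives -7.95%. These two differ in more than one place, so only their two values can be set side by side. Compound 3 `CCCCCCCCCCCCCC[C@H](OCOC)[C@H](CN1CCN(C)CC1)NC(=O)OC(C)(C)C` has not yet been tested. It carries 4-methylpiperazin-1-yl in place of diisopropylamino on a saturated chain carbon, two bonds along the chain from an amide-type nitrogen. For the measured compounds named here, no measured pair isolates this change, so the account rests on compound 2 alone. The expected step of a number 3.1 percentage points higher from compound 2 to compound 3 (within the scatter) is small, staying within the usual scatter or rising only slightly. The estimate for compound 3 in this assay is 30%, with a range from 5% to 55%.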

Compound 3, a percentage reported as inhibition, at one concentration (the size of the read-out at that concentration, not a potency): 28%
The estimate for compound 3 lay 2 percentage points above the measured number, and the stated range covers the measured number.
By their numbers in this assay, from the lowest: compound 1; then compounds 2 and 3 (each within the scatter of the next).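

In this assay, putting 4-methylpiperazin-1-yl in place of diisopropylamino on a saturated chain carbon, two bonds along the chain from an amide-type nitrogen, gives a step of a number 1.1 percentage points higher from compound 2 to compound 3 (within the scatter) and so does not separate the two amines. Among the compounds shown here, compound 2 and compound 3 are the first pair here to differ in one place only, and they show that this position accepts a six-membered non-aromatic ring in place of the open-chain amine with no change that can be told from the scatter. Nothing measured alongside these compounds speaks to the reason for this result.

Going by these compounds, whether a morpholine or a primary amine at this place would read the same remains open. So does whether the amine arm would hold its reading with a free amine in place of the tert-butyl carbamate.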